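This account rests on a few compounds, and the source may have more. Where it says the series, first, only, none or still open, it means among the compounds named here.

The measured compounds:
compound 1, `CN1CCCN(CCn2ccc3ccc(Br)cc32)CC1`, gives 31 nM in an assay on HEK293 cells for binding affinity to 5-hydroxytryptamine receptor 7 (Homo sapiens), read by radioligand binding; on this read-out lower numbers stand for stronger inhibition and higher numbers for weaker inhibition
compound 2, `CN1CCCN(CCn2ccc3ccc(F)cc32)CC1`, gives 288 nM in this assay
compound 3, `C=Cc1ccc2ccn(CCN3CCCN(C)CC3)c2c1`, gives 109 nM in this assay

For the measured compounds named here, all three share one core and differ only in the single group that sits on the aromatic ring. Compound 3 stands in the middle of the three numbers: going from the fluoro compound there is a 2.6-fold lower number from compound 2 to compound 3 (0.42 log units; beyond the scatter), while going from the bromo compound there is a 3.5-fold higher number from compound 1 to compound 3 (0.55 log units; beyond the scatter), so compound 3 is separated from both neighbours by more than the scatter.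

Compound 4, `C#Cc1ccc2ccn(CCN3CCCN(C)CC3)c2c1`, differs from compound 3 by ethynyl in place of vinyl on an aromatic carbon. Going by the values given here, no measured step swaps vinyl for ethynyl, so the only guidance comes from the steps that introduced vinyl in the first place, a 3.5-fold higher number from compound 1 to compound 3 (0.55 log units; beyond the scatter) and a 2.6-fold lower number from compound 2 to compound 3 (0.42 log units; beyond the scatter), both modest in size. Since the group leaving and the group entering are each a two-carbon chain without ring or polar atoms, the expected step in this assay is small, with no clear direction and most likely within the scatter, that is a 1.1-fold lower number from compound 3 to compound 4 (0.04 log units; within the scatter). Compound 4 is therefore estimated at 100 nM, with a likely range from 40 nM to 300 nM.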

Compound 4, inhibition constant: 140 nM
Compound 4: middle estimate off by 1.4-fold (0.15 log units), on the low side; the range from low to high includes it.
By their numbers in this assay, from the lowest: compound 1; then compounds 3 and 4 (each within the scatter of the next); then compound 2.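

In this assay, trading the double bond of vinyl for the triple bond of ethynyl, with the chain still at two carbons, gives a 1.3-fold higher number from compound 3 to compound 4 (0.11 log units; within the scatter) and so leaves the number unchanged within the scatter at this position. Ethynyl also shares the intermediate standing of vinyl, with a 4.5-fold higher number from compound 1 to compound 4 (0.65 log units; beyond the scatter) on one side and a 2.1-fold lower number from compound 2 to compound 4 (0.31 log units; beyond the scatter) on the other, so both two-carbon groups fall clearly between bromo and fluoro. Nothing measured here explains why these groups differ.

The compounds shown leave open how chloro or iodo would compare with bromo on this aromatic carbon. They also leave open whether a longer chain such as propyl, an amine or a carboxylic acid there would keep the number in this same range.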